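Drawing one stereocentre as S in compound 3

A few compounds are considered here, and "the series" means these few. Any claim that something is new, unique, unknown or untested is made for them only; others in the source may bear on it.

In an ADME assay on liver (Mus musculus) for metabolic stability, read by LC-MS, using microsomes and NADPH (on this read-out lower numbers stand for a less stable compound and higher numbers for a more stable compound), these compounds were measured:
- compound 1 `CCCN(Cc1ccc(OCCN2C(=O)CCC2=O)c(C)c1)[C@@H](CC(=O)O)c1ccc(Cl)cc1` gives 97%
- compound 2 `CCN(Cc1ccc(OCCN2C(=O)CCC2=O)c(C)c1)C(CC(=O)O)c1ccc(Cl)cc1` gives 88%
- compound 3 `Cc1cc(CN(CC2CC2)C(CC(=O)O)c2ccc(Cl)cc2)ccc1OCCN1C(=O)CCC1=O` gives 83%

Compound 3 (83%) lies within the scatter of compound 2 and clearly under compound 1 (97%). Compound 4 `Cc1cc(CN(CC2CC2)[C@@H](CC(=O)O)c2ccc(Cl)cc2)ccc1OCCN1C(=O)CCC1=O` is still unmeasured. It differs from compound 3 only in how it is drawn (the two compounds have the same atoms and bonds; at least one stereo element is drawn with a configuration in one of them and without one in the other: 1 of 1 stereo elements differ; a stereocentre at a saturated chain carbon is drawn without a configuration in compound 3 and S in compound 4): a stereocentre at a saturated chain carbon is drawn without a configuration in compound 3 and S in compound 4. Among the measured compounds shown here, the one measured step is a number 5 percentage points lower from compound 2 to compound 3 (within the scatter) and it concerns a different change. For the measured compounds named here, no measured step alters a stereocentre alone, so no shift beyond the scatter is expected in this assay. The expected size is a number 3 percentage points higher from compound 3 to compound 4 (within the scatter) and this stays within the scatter. Compound 4 is estimated at 86% (range 75% to 97%).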

Compound 4, percent of the compound remaining: 87%
Beside the measured number, compound 4's estimate is 1 percentage points below it, within the range that was stated.
By their numbers in this assay, from the lowest: compounds 3, 4, 2 and 1 (each within the scatter of the next, the first and the last beyond it).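

In this assay, defining the stereocentre as S leaves the stability reading within the scatter: a number 4 percentage points higher from compound 3 to compound 4 (within the scatter). With this S configuration drawn in both compounds, the swap of ethyl for cyclopropyl also stays within the scatter: a number 10 percentage points lower from compound 1 to compound 4 (within the scatter). The first of these steps rests on a difference of drawing alone: the fact that one of compounds 3 and 4 is drawn with a defined configuration and the other without, at the place where they differ.

Still open, from the compounds shown here alone, is how the opposite configuration at this stereocentre would read. Also open, going by these compounds, is whether cyclobutyl or a longer chain bound to the amine nitrogen would stay within the scatter too.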